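Swapping a protected amine for a benzyl group

The compounds below may be only part of what the source reports. "The series", "measured", "known", "first", "only" and "open" are said of these compounds alone.

- compound 1, `CCCSc1nc(Cl)c2c(n1)N(Cc1ccccc1)C(C(=O)NCCNC(=O)OC(C)(C)C)N2`, recorded in a functional assay on MGC-803 cells (Homo sapiens) for antiproliferative activity, read by MTT assay, with a stated time of 72 h (on this read-out lower numbers stand for stronger inhibition and higher numbers for weaker inhibition), only as a limit, > 64000 nM
- compound 2, `CCCSc1nc(Cl)c2c(n1)N(Cc1ccccc1)C(C(=O)Nc1ccccc1)N2`, 58400 nM
- compound 3, `CCCSc1nc(Cl)c2c(n1)N(Cc1ccccc1)C(C(=O)NCCC1=CCc3ccccc31)N2`, 27000 nM

Compound 1 stands at the weak end of the three measured compounds in this assay: its result is a limit, (the limit of > 64000 nM in this assay, at which 1 of the 3 values shown sits), so no number is known for it. Compound 2 and compound 3 gave numbers. The step of an at least 1.0-fold lower number from compound 1 to compound 2 (0.03 log units; that floor lies within the scatter) reaches only a floor within the scatter, whereas an at least 2.3-fold lower number from compound 1 to compound 3 (0.37 log units; beyond the scatter) and a 2.2-fold lower number from compound 2 to compound 3 (0.34 log units; beyond the scatter) are modest steps toward stronger inhibition.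

Compound 4, `CCCSc1nc(Cl)c2c(n1)N(Cc1ccccc1)C(C(=O)NCCCc1ccccc1)N2`, is not yet measured. It differs from compound 1 in one place: benzyl in place of (tert-butoxycarbonyl)amino on a saturated chain carbon, two bonds along the chain from an amide-type nitrogen. The two measured steps away from compound 1 bear on this change, since both replace the same part of the amide side chain with a group carrying an aromatic ring. Because an at least 2.3-fold lower number from compound 1 to compound 3 (0.37 log units; beyond the scatter) lies beyond the scatter while an at least 1.0-fold lower number from compound 1 to compound 2 (0.03 log units; that floor lies within the scatter) does not, a modest step toward a lower number is expected for compound 4, an at least 1.8-fold lower number from compound 1 to compound 4 (0.26 log units; that floor lies within the scatter), though a result that again stops at the limit cannot be ruled out. Compound 4 is therefore estimated at 35000 nM, within a range from 15000 nM to 90000 nM.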

Compound 4, half-maximal inhibitory concentration: 16900 nM
For compound 4 the middle estimate is 2.1-fold (0.32 log units) above the measured one; measured number inside the range.
By their numbers in this assay, from the lowest: compounds 4 and 3 (each within the scatter of the next); then compound 2. At a limit, above all of these: compound 1.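

Compound 1 is still known only as a limit: the limit of > 64000 nM in this assay, at which 1 of the 4 values shown sits.

Even so, benzyl in place of (tert-butoxycarbonyl)amino on this saturated chain carbon gives an at least 3.7-fold lower number from compound 1 to compound 4 (0.57 log units; beyond the scatter), and 3-phenylpropyl in place of phenyl on the amide-type nitrogen gives a 3.5-fold lower number from compound 2 to compound 4 (0.54 log units; beyond the scatter), so in this assay the aromatic ring carried at the end of a chain in compound 4 does better than the one set directly on that nitrogen in compound 2. The exact form of the chain end matters less in this small set, with a 1.6-fold lower number from compound 3 to compound 4 (0.20 log units; within the scatter), which means that the open 3-phenylpropyl group of compound 4 and the group of compound 3, with its additional five-membered non-aromatic ring, cannot be told apart.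

On these data alone, whether a free amine or a carboxylic acid at the end of this chain, or a chain longer than 3-phenylpropyl, would shift the number further remains open. As far as these compounds go, it is also open whether a chlorine atom or a methoxy group on the phenyl ring of 3-phenylpropyl would change the result, and how much of the gain from compound 1 is real remains unknown while its value is only a limit.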